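From isopropyl to butyl on the benzyl side

A few compounds are considered here, and "the series" means these few. Any claim that something is new, unique, unknown or untested is made for them only; others in the source may bear on it.

Among the compounds with values here, in a functional assay on the whole organism for inhibition, with Rattus norvegicus as the target (on this read-out lower numbers stand for an effect already at smaller amounts and higher numbers for an effect only at larger amounts of compound), compound 2 `CC(C)c1ccc(CC(C)(Oc2ccc(C(C)C)cc2)C(=O)O)cc1` gives 5 mg/kg, the only actual number so far. Compound 1 `CC(C)c1ccc(OC(C)(Cc2ccccc2)C(=O)O)cc1` gives > 10 mg/kg, which is a limit of the assay. Within the data shown here, the one measured step, an at least 2.0-fold lower number from compound 1 to compound 2 (0.30 log units; that floor lies within the scatter), is therefore known only as a floor, given (the limit of > 10 mg/kg in this assay, at which 1 of the 2 values shown sits). That step placed isopropyl on the aromatic carbon where the next change falls.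

Compound 3 `CCCCc1ccc(CC(C)(Oc2ccc(C(C)C)cc2)C(=O)O)cc1` keeps the rest of compound 2 and differs at that one place: butyl in place of isopropyl on an aromatic carbon. It carries butyl in place of isopropyl on an aromatic carbon, para to a large group. Among the measured compounds shown here, the step of an at least 2.0-fold lower number from compound 1 to compound 2 (0.30 log units; that floor lies within the scatter) is the only guide, and it replaced hydrogen, whereas here one group without a ring gives way to another. No large shift is therefore expected from compound 2 at 5 mg/kg, and neither direction is favoured. The expected step, which should stay near the scatter, is no change at the digits printed from compound 2 to compound 3 (within the scatter). Compound 3 is estimated at 5 mg/kg, with an expected range of 2 mg/kg to 12 mg/kg.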

Compound 3, dose for half-maximal effect: 1 mg/kg
Estimate against measurement, compound 3: 5.0-fold (0.70 log units) above; the whole stated range lies above it.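

At this aromatic carbon, para to a large group, the result shows that the read-out depends on which group without a ring is present, and not only on whether hydrogen has been replaced: in this assay, butyl in place of isopropyl gives a 5.0-fold lower number from compound 2 to compound 3 (0.70 log units; beyond the scatter). The replacement of hydrogen can now also be read beyond the scatter, since butyl at the same carbon gives an at least 10-fold lower number from compound 1 to compound 3 (1.00 log units; beyond the scatter), whereas the floor for isopropyl lay within it. Compound 1 gives > 10 mg/kg, which is a limit of the assay, so the full size of this second step remains unknown and only its floor can be stated: the limit of > 10 mg/kg in this assay, at which 1 of the 3 values shown sits.

The compounds shown leave open whether the difference between compound 2 and compound 3 goes with the length of the chain or with the absence of branching, as one pair cannot separate the two. On these data alone, how an unbranched propyl, a longer chain such as hexyl, or an amine at this carbon would read out also remains open, measured against the result that compound 3 gives 1 mg/kg.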